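A few compounds are considered here, and "the series" means these few. Any claim that something is new, unique, unknown or untested is made for them only; others in the source may bear on it.

Working notes on the series. Of the compounds shown here, three have been measured in an assay on CHO cells for antagonist activity at transient receptor potential cation channel subfamily V member 1 (Homo sapiens), read by FLIPR; a higher number here means a weaker inhibitor, a lower number a stronger inhibitor. Compound 1, `CCCCCCOc1cc(C(C)(F)F)ccc1CNC(=O)C(C)c1ccc(NS(C)(=O)=O)c(F)c1`, gives 0.8 nM. Compound 2, `CC(C(=O)NCc1ccc(C(F)(F)F)cc1OC1CCCCC1)c1ccc(NS(C)(=O)=O)c(F)c1`, gives 0.7 nM. Compound 3, `C[C@H](C(=O)NCc1ccc(C(F)(F)F)cc1SC1CCCCC1)c1ccc(NS(C)(=O)=O)c(F)c1`, gives 0.3 nM. Compound 2 stands second highest of the three numbers: its nearest neighbour is compound 1, whose number is only slightly higher and within the scatter of the method, so no order between compound 1 and compound 2 can be read from this; its furthest neighbour is compound 3, whose lower number lies beyond the scatter. For the measured compounds named here, no step between measured compounds differs in one place only, so nothing is known from the measured set about swapping the group on the aromatic carbon.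

The next compound, compound 4, `CC(C(=O)NCc1ccc(C(F)(F)F)cc1-c1ccc(F)c(Cl)c1)c1ccc(NS(C)(=O)=O)c(F)c1`, has not yet been measured in this assay. It differs from compound 2 in one place: 3-chloro-4-fluorophenyl in place of cyclohexyloxy on an aromatic carbon. Going by the values given here, since no measured pair shows what this kind of exchange does, the expected step of a 3.6-fold higher number from compound 2 to compound 4 (0.55 log units; beyond the scatter) is set as a moderate rise in number, that is a somewhat weaker inhibitor, with wide uncertainty in both directions. On that basis compound 4 is expected to give about 2.5 nM, within a range from 0.5 nM to 12 nM in this assay.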

Compound 4, inhibition constant: 0.6 nM
Compound 4: middle estimate off by 4.2-fold (0.62 log units), on the high side; the measured number falls inside the stated range.
By their numbers in this assay, from the lowest: compounds 3, 4, 2 and 1 (each within the scatter of the next, the first and the last beyond it).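

In this assay, for the compounds shown here, replacing cyclohexyloxy with 3-chloro-4-fluorophenyl on the aromatic carbon ortho to a large group and meta to a trifluoromethyl group gives a 1.2-fold lower number from compound 2 to compound 4 (0.07 log units; within the scatter), the only single-place step at this position, and no difference between the two groups can be read from it. This position therefore tolerates both a non-aromatic carbon ring attached through oxygen and a halogen-bearing aromatic ring attached directly, with no loss beyond the scatter on this exchange. No measured evidence bears on why the two groups read alike here.

The compounds shown leave open whether the chlorine and fluorine matter to this result, as unsubstituted phenyl does not appear among them, and whether the tolerance holds for a group of a different kind at the same carbon, such as a piperidine amine or a carboxylic acid. With a single step at this position, they also leave open whether the same exchange would read alike on a core differing elsewhere.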